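The compounds below may be only part of what the source reports. "The series", "measured", "known", "first", "only" and "open" are said of these compounds alone.

Measured compounds:
compound 1 `CCOC(=O)c1c(-c2ccc(Cl)cc2)cc(-c2ccccc2)nc1N1CCCCC1`, which in a functional assay on the whole organism (strain Wister albino) for inhibition, with Rattus norvegicus as the target, read by paw edema, with stated times of 1 h and 4 h, at a dose of 50 mg/kg by the intraperitoneal route (a higher number here means more inhibition at the dose given (going by the name of the read-out), a lower number less inhibition), gives 103%
compound 2 `CCOC(=O)c1c(-c2ccc(Cl)c(Cl)c2)cc(-c2ccccc2)nc1N1CCCCC1`, which in this assay gives 95.1%
compound 3 `CCOC(=O)c1c(-c2ccc(Cl)cc2)cc(-c2ccccc2)nc1Nc1ccc(Cl)cc1`, which in this assay gives 95.9%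

The three numbers sit close together. The change from compound 1 to compound 2 is chloro in place of hydrogen on an aromatic carbon, and it moved the read-out by a number 7.9 percentage points lower from compound 1 to compound 2 (within the scatter). Compound 3 differs from compound 1 in its core by (4-chlorophenyl)amino in place of piperidin-1-yl on an aromatic carbon, a change that moved the read-out by a number 7.1 percentage points lower from compound 1 to compound 3 (within the scatter).

Compound 4 `CCOC(=O)c1c(-c2ccc(Cl)c(Cl)c2)cc(-c2ccccc2)nc1Nc1ccc(Cl)cc1` has not yet been measured in this assay. Relative to compound 3 it carries chloro in place of hydrogen on an aromatic carbon. The place is described in the same words as for the change from compound 1 to compound 2, so this is the same change applied to the core of compound 3. The expected step is a number 6.9 percentage points lower from compound 3 to compound 4 (within the scatter), close to the earlier one, because compound 2 showed a number 7.9 percentage points lower from compound 1 to compound 2 (within the scatter) and compound 3 already starts from 95.9%. Compound 4 is therefore estimated at 89%, with a likely range from 76% to 101%.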

Compound 4, a percentage reported as inhibition, in the whole organism at one dose (the size of the read-out at that dose, not a potency): 91.8%
Compound 4: middle estimate off by 2.8 percentage points, on the low side, within the range that was stated.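

In this assay, the change from 4-chlorophenyl to 3,4-dichlorophenyl on the core of compound 3 gave a number 4.1 percentage points lower from compound 3 to compound 4 (within the scatter), and it compares with the same change on the core of compound 1 as follows: the same change on two cores in this assay, a number 7.9 percentage points lower (within the scatter) from compound 1 to compound 2 and a number 4.1 percentage points lower (within the scatter) from compound 3 to compound 4, 3.8 percentage points apart, within the scatter of two such steps. The replacement of piperidin-1-yl by (4-chlorophenyl)amino, read on the dichlorinated core, gave a number 3.3 percentage points lower from compound 2 to compound 4 (within the scatter), and it compares with its earlier counterpart as follows: the same change on two cores in this assay, a number 7.1 percentage points lower (within the scatter) from compound 1 to compound 3 and a number 3.3 percentage points lower (within the scatter) from compound 2 to compound 4, 3.8 percentage points apart, within the scatter of two such steps. Each change thus looks the same on the two cores, but every step lies within the scatter, so the four compounds show neither that either change has a real effect on the read-out nor that such effects would add up in other members of the series.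

Going by these compounds, all four compounds keep the ethyl ester and the unsubstituted phenyl group, so it remains open how a carboxylic acid or an amide in place of the ester would read. Also open, on these data alone, are a morpholine in place of the piperidine and a fluoro or methoxy group in place of the chloro.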